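A few compounds are considered here, and "the series" means these few. Any claim that something is new, unique, unknown or untested is made for them only; others in the source may bear on it.

Working notes on the series. Compound 2 `CC(=O)SCC(=O)c1ccc(NS(=O)(=O)c2ccc(OCCCN3CCCC3)cc2)nc1` gives 820 nM in a functional assay on HCT-116 cells (Homo sapiens) for cytotoxicity; on this read-out higher numbers stand for an effect only at larger amounts of compound and lower numbers for an effect already at smaller amounts; among the three numbers it is the second highest, yet compound 3 `CC(=O)SCC(=O)c1ccc(NS(=O)(=O)c2ccc3c(c2)COOC3)nc1` at 1200 nM and compound 1 `CC(=O)SCC(=O)c1ccc(NS(=O)(=O)c2ccc(OCc3ccccn3)cc2)nc1` at 420 nM both lie within the scatter of it. Compound 4 `CC(=O)SCC(=O)c1ccc(NS(=O)(=O)c2ccc(OC3CCN(C)CC3)cc2)nc1` is not yet measured; it differs from compound 2 by 1-methylpiperidin-4-yl in place of 3-(pyrrolidin-1-yl)propyl on an oxygen on an aromatic ring. For the measured compounds named here, only one measured step touches that oxygen: a 2.0-fold higher number from compound 1 to compound 2 (0.29 log units; within the scatter), which stayed within the scatter. With one such comparison available and no step beyond the scatter anywhere in the three compounds, no change beyond the scatter is expected in this assay for the step of a 1.0-fold lower number from compound 2 to compound 4 (0.01 log units; within the scatter). Compound 4 is therefore estimated at 800 nM, with a range from 300 nM to 2200 nM.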

Compound 4, half-maximal effective concentration: 180 nM
Compound 4: middle estimate off by 4.4-fold (0.65 log units), on the high side; the whole stated range lies above it.
By their numbers in this assay, from the lowest: compound 4; then compounds 1, 2 and 3 (each within the scatter of the next, the first and the last beyond it).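

At the oxygen on an aromatic ring, the group clearly matters in this assay: 1-methylpiperidin-4-yl in place of 3-(pyrrolidin-1-yl)propyl gives a 4.6-fold lower number from compound 2 to compound 4 (0.66 log units; beyond the scatter) and stands beyond the scatter, as does its replacement of (pyridin-2-yl)methyl with a 2.3-fold lower number from compound 1 to compound 4 (0.37 log units; beyond the scatter). The only earlier step at this oxygen, between compound 1 and compound 2, had shown no change beyond the scatter. Nothing available explains the change. Still open, going by these compounds, is whether the step rests on the ring or on its methyl: a piperidin-4-yl without that methyl, or a 1-methylpyrrolidin-3-yl, on the same oxygen would separate the two.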